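Chain extension with a basic amine on the shared core

The source may hold more compounds than are shown below. What is called first, only, known or untested is meant among the compounds shown, and "the series" means these compounds.

Of the compounds shown here, three with the shared core have been measured in a functional assay on A-375 cells (Homo sapiens) for cytotoxicity, read by MTT assay, with a stated time of 72 h; on this read-out lower numbers stand for stronger inhibition and higher numbers for weaker inhibition. Compound 1 `O=C1c2c[n+]([O-])c3ccccc3c2C(=O)c2c1c1ccccc1n2CCCCn1ccnc1` gives 350 nM and stands second highest of the three numbers. Compound 2 `O=C1c2c[n+]([O-])c3ccccc3c2C(=O)c2c1c1ccccc1n2CCCCN1CCCCC1` gives 190 nM, and the step of a 1.8-fold lower number from compound 1 to compound 2 (0.27 log units; within the scatter) is within the scatter. Compound 3 `CCCN1CCN(CCCCn2c3c(c4ccccc42)C(=O)c2c[n+]([O-])c4ccccc4c2C3=O)CC1` gives 870 nM; the step of a 2.5-fold higher number from compound 1 to compound 3 (0.40 log units; beyond the scatter) is a modest weakening, and a 4.6-fold higher number from compound 2 to compound 3 (0.66 log units; beyond the scatter) points the same way.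

Compound 4 `CN1CCN(CCCCCCn2c3c(c4ccccc42)C(=O)c2c[n+]([O-])c4ccccc4c2C3=O)CC1` has not been measured. Relative to compound 1 the change is 2-(4-methylpiperazin-1-yl)ethyl in place of 1H-imidazol-1-yl on a saturated chain carbon, four bonds along the chain from an aromatic nitrogen. The most relevant comparison is the step from compound 1 to compound 3, where a piperazine carrying an alkyl group entered in place of the imidazole and the number rose beyond the scatter, whereas the piperidine of compound 2 left the number within the scatter. The entering group in compound 4 again carries a piperazine, now on a longer chain, so a modest rise is expected rather than none. For compound 4 the expected step is a 1.9-fold higher number from compound 1 to compound 4 (0.27 log units; within the scatter). Compound 4 is estimated at 650 nM, with a range from 250 nM to 1700 nM.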

Compound 4, half-maximal inhibitory concentration: 630 nM
For compound 4 the middle estimate is 1.0-fold (0.01 log units) above the measured one; the measured number falls inside the stated range.
By their numbers in this assay, from the lowest: compounds 2, 1, 4 and 3 (each within the scatter of the next, the first and the last beyond it).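

With 2-(4-methylpiperazin-1-yl)ethyl at this place on a saturated chain carbon, a 1.8-fold higher number from compound 1 to compound 4 (0.26 log units; within the scatter) does not separate the new compound from the imidazole, unlike the propylpiperazine of compound 3, and a 1.4-fold lower number from compound 3 to compound 4 (0.14 log units; within the scatter) does not separate the two piperazine compounds. The piperidine remains apart from both piperazine compounds: a 3.3-fold higher number from compound 2 to compound 4 (0.52 log units; beyond the scatter) sits alongside a 4.6-fold higher number from compound 2 to compound 3 (0.66 log units; beyond the scatter) and gives a second case of a piperazine compound lying beyond the scatter from compound 2 in this small set. No measurement offered here accounts for these steps.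

Compound 4 differs from compound 3 in both the chain and the alkyl group on the piperazine, so the contribution of each remains unresolved. Open too, on these data alone, are a methyl group on the piperazine with the shorter chain of compound 3, a propyl group with the longer chain of compound 4, and a morpholine at the chain end.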